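This account rests on a few compounds, and the source may have more. Where it says the series, first, only, none or still open, it means among the compounds named here.

Working notes on a fused-core series tested in a functional assay on CHO cells for antagonist activity at adenosine receptor A2b (Homo sapiens), read by 33P incorporation, with a stated time of 20 min; a lower number here means a stronger inhibitor, a higher number a weaker inhibitor. Compound 1 `Cn1c(-c2ccc(F)cc2)nc2c(NC3CCCC3)ncnc21` returns > 30000 nM in this assay, a limit of the assay and not a number. Compound 2 `Cn1c(-c2ccccc2)nc2c(NC3CCCCC3)ncnc21` likewise returns only a limit, > 30000 nM. Compound 3 `CCn1c(-c2ccccc2)nc2c(NC3CCOC3)ncnc21` gives a number, 11500 nM, the only one in the set. Among the measured compounds shown here, compound 1 therefore stands at the limit of > 30000 nM in this assay, at which 2 of the 3 values shown sit, so no step from it can be read with any size. Compound 4 `Cn1c(-c2cccnc2)nc2c(NC3CCCC3)ncnc21` carries pyridin-3-yl in place of 4-fluorophenyl on an aromatic carbon. For the measured compounds named here, no measured pair shows a change of this kind, and compound 1 supplies no number to anchor a step. The step from compound 1 to compound 4 is expected to be no larger than the scatter, at most a modest gain, as a number no higher from compound 1 to compound 4 (the limit leaves the size open). Compound 4 is expected to give 30000 nM in this assay, within 8000 nM to 100000 nM.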

Compound 4, inhibition constant: > 30000 nM
Compound 4 was reported as a limit; the forecaster's own chance of this, stated with the estimate: 60%; the middle value lies on the limit itself.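

Compound 1 and compound 4 both return only a limit in this assay, so no step between them can be read: the limit of > 30000 nM in this assay, at which 3 of the 4 values shown sit.

The compounds shown leave open whether pyridin-3-yl in place of 4-fluorophenyl shifts the inhibition constant at all.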